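The source may report more compounds than this note shows. Statements on the series, on what has been measured and on what is new or still open speak of the compounds shown alone.

Of the compounds shown here, three built on one shared core have been measured in a functional assay for inhibition of sodium/hydrogen exchanger (Oryctolagus cuniculus); a lower number here means a stronger inhibitor, a higher number a weaker inhibitor. Compound 1 `Cc1cc(F)c(S(C)(=O)=O)cc1C(=O)N=C(N)N` gives 44 nM, compound 2 `Cc1cc(O)c(S(C)(=O)=O)cc1C(=O)N=C(N)N` gives 220 nM, and compound 3 `Cc1cc(OC2CCCCC2)c(S(C)(=O)=O)cc1C(=O)N=C(N)N` gives 37 nM. Compound 3 shows the lowest of the three numbers, but its gap to compound 1, a 1.2-fold lower number from compound 1 to compound 3 (0.08 log units; within the scatter), is within the scatter, so those two cannot be ranked; only compound 2 stands apart, through a 5.9-fold lower number from compound 2 to compound 3 (0.77 log units; beyond the scatter) and a 5.0-fold higher number from compound 1 to compound 2 (0.70 log units; beyond the scatter).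

Compound 4 `Cc1cc(-n2ccnc2C)c(S(C)(=O)=O)cc1C(=O)N=C(N)N` differs from compound 3 in one place: 2-methyl-1H-imidazol-1-yl in place of cyclohexyloxy on an aromatic carbon. Among the measured compounds shown here, the steps that bear on this are the two that change the group at the same place, from compound 1 and from compound 2 to compound 3. They show that cyclohexyloxy and fluoro give similar numbers, while hydroxy gives a higher one. For the measured compounds named here, no measured step puts an aromatic group there, so the guidance is indirect. The change expected in this assay is small, a 1.6-fold higher number from compound 3 to compound 4 (0.21 log units; within the scatter). Compound 4 is expected to give about 60 nM, within a range from 15 nM to 250 nM.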

Compound 4, half-maximal inhibitory concentration: 29 nM
Compound 4: the middle estimate sits 2.1-fold (0.32 log units) above what was measured, within the range that was stated.
By their numbers in this assay, from the lowest: compounds 4, 3 and 1 (each within the scatter of the next); then compound 2.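

In this assay, this aromatic carbon, ortho to a methylsulfonyl group, also accepts an aromatic ring: 2-methyl-1H-imidazol-1-yl cannot be told apart from cyclohexyloxy (a 1.3-fold lower number from compound 3 to compound 4 (0.11 log units; within the scatter)) or from fluoro (a 1.5-fold lower number from compound 1 to compound 4 (0.18 log units; within the scatter)). Hydroxy remains the one group that stands apart (a 7.6-fold lower number from compound 2 to compound 4 (0.88 log units; beyond the scatter)), so a five-membered aromatic ring, a six-membered ring of carbon only and a single fluoro all give numbers within the scatter of one another, with compound 2 as the exception. No outside data bear on this result, so no reason for it can be given.

The compounds shown leave open whether the methyl of the 2-methyl-1H-imidazol-1-yl group matters, since no compound has an imidazolyl group without it. They also leave open whether a phenyl ring, an amine or a small methoxy group here would match compound 4 or compound 2.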